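A fluorine-for-chlorine swap on a shared pyrimidine core

The compounds below may be only part of what the source reports. "The series", "measured", "known", "first", "only" and "open" are said of these compounds alone.

Of the compounds shown here, two have been measured in a functional assay on HepG2 cells (Homo sapiens) for cytotoxicity, read by MTT assay, with a stated time of 48 h; a higher number here means a weaker inhibitor, a lower number a stronger inhibitor. Compound 1 `CN1CCN(c2ccc(Nc3ncc(F)c(NC4CCCC4)n3)cc2)CC1` gives 25000 nM, and compound 2 `CN1CCC(NC(=O)c2ccc(Nc3ncc(Cl)c(NC4CCCC4)n3)cc2)CC1` gives 2200 nM. Compound 2 therefore holds the lower of the two numbers, and compound 1 sits at a higher value that lies well beyond the usual scatter. The two compounds differ in more than one place, so their gap cannot be pinned on any single change.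

Compound 3 `CN1CCC(NC(=O)c2ccc(Nc3ncc(F)c(NC4CCCC4)n3)cc2)CC1` has not yet been measured. It is derived from compound 2 by a single change: fluoro in place of chloro on an aromatic carbon. For the measured compounds named here, with no measured pair isolating this swap, the direction is uncertain; the expectation is a modest move toward a weaker inhibitor, with the possibility that it stays within the scatter. Compound 3 is estimated at 5000 nM, with a range from 1500 nM to 16000 nM, which would mean a step of a 2.3-fold higher number from compound 2 to compound 3 (0.36 log units; beyond the scatter).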

Compound 3, half-maximal inhibitory concentration: 10000 nM
Beside the measured number, compound 3's estimate is 2.0-fold (0.30 log units) below it; the measured number falls inside the stated range.
By their numbers in this assay, from the lowest: compound 2; then compound 3; then compound 1.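

In this assay, the halogen on the shared core now has a reading of its own: fluoro in place of chloro, on the aromatic carbon ortho to a cyclopentylamino group, gives a 4.5-fold higher number from compound 2 to compound 3 (0.66 log units; beyond the scatter) and so moves toward a weaker inhibitor. A second single change can also be read, as (1-methylpiperidin-4-yl)carbamoyl in place of 4-methylpiperazin-1-yl gives a 2.5-fold lower number from compound 1 to compound 3 (0.40 log units; beyond the scatter) and moves toward a stronger inhibitor. The wide gap between the first two compounds thus splits into two separate steps, each beyond the scatter.

The compounds shown leave open where a bromo or a methyl group on this carbon would fall, and whether the chloro-to-fluoro step keeps its size alongside 4-methylpiperazin-1-yl. Why either step occurs also stays open, and nothing measured here bears on it.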